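Ethyl in Place of Trifluoromethyl on a Shared Core

The source may hold more compounds than are shown below. What is called first, only, known or untested is meant among the compounds shown, and "the series" means these compounds.

Of the compounds shown here, three sharing one core have been measured in a physicochemical assay for permeability; on this read-out higher numbers stand for higher permeability and lower numbers for lower permeability: compound 1 `Clc1ccc(NC2=NCCC3(CCCCC3)S2)cc1`, compound 2 `FC(F)(F)c1ccc(NC2=NCCC3(CCCCC3)S2)cc1` and compound 3 `CC(=O)c1cccc(NC2=NCCC3(CCCCC3)S2)c1`. In this assay compound 1 gives 27.8 10^-6 cm/s, compound 2 gives 3.06 10^-6 cm/s and compound 3 gives 74.7 10^-6 cm/s. Compound 2 therefore stands lowest of the three numbers; compound 1 is its nearest neighbour and compound 3 its furthest, both beyond the scatter.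

The step now followed leads from compound 2 to compound 4 `CCc1ccc(NC2=NCCC3(CCCCC3)S2)cc1`, which has not yet been measured: ethyl in place of trifluoromethyl on an aromatic carbon.

Going by the values given here, only one measured step involves the group that leaves. a 9.1-fold lower number from compound 1 to compound 2 (0.96 log units; beyond the scatter) shows that exchanging the substituent on this aromatic carbon moved this assay well beyond the scatter, and the trifluoromethyl compound came out lowest. Among the compounds with values here, no measured pair shows ethyl entering, so the size of the present step is uncertain; still, since compound 2 sits lowest and its only neighbour without trifluoromethyl, compound 1, gives 27.8 10^-6 cm/s, an upward step is expected. The step of a 6.5-fold higher number from compound 2 to compound 4 (0.82 log units; beyond the scatter) is thus expected to lift the number back toward compound 1. Compound 4 is estimated to give 20 10^-6 cm/s in this assay, within a range from 6 10^-6 cm/s to 60 10^-6 cm/s.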

Compound 4, apparent permeability: 41 10^-6 cm/s
Compound 4: middle estimate off by 2.1-fold (0.31 log units), on the low side, within the range that was stated.
By their numbers in this assay, from the lowest: compound 2; then compounds 1, 4 and 3 (each within the scatter of the next, the first and the last beyond it).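

In this assay, putting ethyl in place of trifluoromethyl on this aromatic carbon, para to a large group, gives a 13-fold higher number from compound 2 to compound 4 (1.13 log units; beyond the scatter), a large step that reverses the drop seen when trifluoromethyl replaced chloro, a 9.1-fold lower number from compound 1 to compound 2 (0.96 log units; beyond the scatter). Ethyl in place of chloro, by contrast, gives a 1.5-fold higher number from compound 1 to compound 4 (0.17 log units; within the scatter), so chloro and ethyl cannot be told apart here, and among these three compounds that differ only at this carbon, trifluoromethyl alone stands apart, with both of its steps beyond the scatter. Nothing measured here explains why this one group differs, as no supporting evidence on the cause is available.

On these data alone, three groups are too few to show what sets the trifluoromethyl compound apart, and it remains open whether a methoxy group, a nitrile, an amine or a longer chain such as propyl on this carbon would stay with chloro and ethyl or fall with trifluoromethyl. As far as these compounds go, compound 3 differs from these compounds in more than one place, so whether the same exchanges would give steps of similar size elsewhere on the aromatic ring also remains open.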